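A Urea Analogue of Compound 3 with a Substituted Ring

The compounds below may be only part of what the source reports. "The series", "measured", "known", "first", "only" and "open" are said of these compounds alone.

Compound 1 `O=C(Nc1ccc(-c2noc(-c3cccc(NS(=O)(=O)c4ccccc4)c3)n2)c(Cl)c1)c1cccnc1` — > 10000 nM
Compound 2 `CC(=O)Nc1ccc(S(=O)(=O)Nc2cccc(-c3nc(-c4ccc(NC(=O)c5cccnc5)cc4Cl)no3)c2)cc1Cl` — > 10000 nM
Compound 3 `Cc1ccc(NC(=O)Nc2cccc(-c3nc(-c4ccc(NC(=O)c5cccnc5)cc4Cl)no3)c2)cc1` — 3500 nM

In a functional assay on MDA-MB-231 cells (Homo sapiens) for antiproliferative activity, read by MTT assay, with a stated time of 72 h (a lower number here means a stronger inhibitor, a higher number a weaker inhibitor), compound 1 gives > 10000 nM, which is a limit of the assay rather than a number. Compound 2 likewise gives > 10000 nM, again a limit. Within the data shown here, compound 3 gives 3500 nM and is the only compound with a number; the other two sit at the limit of > 10000 nM in this assay, at which 2 of the 3 values shown sit. Among the measured compounds shown here, the step of an at least 2.8-fold lower number from compound 1 to compound 3 (0.45 log units; beyond the scatter) is the one readable step. Compound 4 `CS(=O)(=O)Nc1ccc(NC(=O)Nc2cccc(-c3nc(-c4ccc(NC(=O)c5cccnc5)cc4Cl)no3)c2)cc1Br` differs from compound 3 in one place: 3-bromo-4-(methanesulfonamido)phenyl in place of 4-methylphenyl on an amide-type nitrogen. For the measured compounds named here, the closest measured step, a step that the two limits leave unreadable from compound 1 to compound 2, also decorates the ring on that nitrogen, but its size is unreadable, so no measured step gives a size for this change. Compound 4 is therefore expected near compound 3, with no change at the digits printed from compound 3 to compound 4 (within the scatter) as the estimated step. The estimate for compound 4 is 3500 nM, ranging from 900 nM to 12000 nM.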

Compound 4, half-maximal inhibitory concentration: 700 nM
For compound 4 the middle estimate is 5.0-fold (0.70 log units) above the measured one, outside the stated range (below it).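

Putting 3-bromo-4-(methanesulfonamido)phenyl on this amide-type nitrogen gives a 5.0-fold lower number from compound 3 to compound 4 (0.70 log units; beyond the scatter) in this assay, the first readable size for a change to the ring at this position. Among these compounds, the earlier change to a ring, on the sulfonyl sulfur, cannot be read, so only this step shows that the number responds to what this ring carries. Nothing shown here explains the step.

On these data alone, compound 4 adds the bromine and the methanesulfonamido group together, so the share of each remains open. Also open, as far as these compounds go, is how an amine or a carboxylic acid on this ring would compare.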